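The source may hold more compounds than are shown below. What is called first, only, known or untested is meant among the compounds shown, and "the series" means these compounds.

Compound 2, `O=C(Cc1csc2nc(-c3ccc(Br)cc3)cn12)N/N=C/c1ccccc1O`, gives 1050 nM in a functional assay on IGROV-1 cells (Homo sapiens) for inhibition, read by sulforhodamine B assay, with a stated time of 48 h (a higher number here means a weaker inhibitor of growth, a lower number a stronger inhibitor of growth), and stands lowest of the two numbers measured; the nearest is compound 1, `O=C(Cc1csc2nc(-c3ccc(Br)cc3)cn12)N/N=C/c1ccccc1`, which gives 11200 nM. For the measured compounds named here, the one step measured, an 11-fold lower number from compound 1 to compound 2 (1.03 log units; beyond the scatter), is large. Compound 3, `O=C(Cc1csc2nc(-c3ccc(Br)cc3)cn12)N/N=C/c1ccc(O)cc1`, differs from compound 2 only in that the hydroxy has moved: 4-hydroxyphenyl in place of 2-hydroxyphenyl on a carbon with a double bond to nitrogen. Going by the values given here, no measured pair shows the 4-hydroxyphenyl, so the step from compound 1 to compound 2 bears on it only indirectly, by showing that the hydroxy on the 2-hydroxyphenyl carries a large gain over hydrogen. Whether the 4-hydroxyphenyl keeps that gain is not known; some of it is expected to be lost, so a moderate rise in this assay is expected, a 2.9-fold higher number from compound 2 to compound 3 (0.46 log units; beyond the scatter). Compound 3 is therefore estimated at 3000 nM, within a range of 800 nM to 12000 nM.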

Compound 3, concentration for 50% growth inhibition: 10700 nM
The estimate for compound 3 lay 3.6-fold (0.55 log units) below the measured number; the range from low to high includes it.
By their numbers in this assay, from the lowest: compound 2; then compounds 3 and 1 (each within the scatter of the next).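

In this assay, the place of the hydroxy decides the outcome, with a 10-fold higher number from compound 2 to compound 3 (1.01 log units; beyond the scatter): the same atoms, joined differently, lose the large gain. The hydroxy in the 4-hydroxyphenyl shows no gain over hydrogen, with a 1.0-fold lower number from compound 1 to compound 3 (0.02 log units; within the scatter), so among these compounds the gain belongs to the 2-hydroxyphenyl and not to a hydroxy on this ring wherever it stands. Nothing shown here explains why the place of the hydroxy matters so much.

The compounds shown leave open whether the gain depends on the hydroxy itself or would survive with a methoxy or an amine in its place on the ring. They also leave open whether a second hydroxy on the 2-hydroxyphenyl would add to the gain or take from it.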